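Trifluoromethyl gives way to hydroxy in a small series

This account rests on a few compounds, and the source may have more. Where it says the series, first, only, none or still open, it means among the compounds named here.

Values measured in a functional assay on HepG2 cells (Homo sapiens) for inhibition, read by MTT assay, with a stated time of 48 h (a lower number here means a stronger inhibitor, a higher number a weaker inhibitor), stand as follows.

Compound 1 `COc1cc(-c2nccn3cc(-c4ccccc4)nc23)cc(OC)c1OC` with 267 nM
Compound 2 `COc1cc(-c2nccn3cc(-c4ccc(C(F)(F)F)cc4)nc23)cc(OC)c1OC` with 2630 nM

Compound 2 holds the higher of the two numbers, which makes it the weaker inhibitor of the pair, and its distance from compound 1 lies beyond the scatter. Compound 3 `COc1cc(-c2nccn3cc(-c4ccc(O)cc4)nc23)cc(OC)c1OC` has not yet been measured. Its change from compound 2 is hydroxy in place of trifluoromethyl on an aromatic carbon and reads in short as hydroxy in place of trifluoromethyl on an aromatic carbon.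

Going by the values given here, one measured step bears on this change. Trifluoromethyl in place of hydrogen on an aromatic carbon gave a 9.9-fold higher number from compound 1 to compound 2 (0.99 log units; beyond the scatter) and this modest step went toward the weaker side. Compound 3 no longer carries trifluoromethyl, so part of that loss is expected to be recovered. Among the compounds with values here, no measured compound carries hydroxy, however, so compound 1 is only a rough guide. The expected change in this assay is a 4.4-fold lower number from compound 2 to compound 3 (0.64 log units; beyond the scatter) and it is expected to run toward a lower number. Compound 3 is estimated at 600 nM (expected range 150 nM to 2500 nM).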

Compound 3, half-maximal inhibitory concentration: 823 nM
For compound 3 the middle estimate is 1.4-fold (0.14 log units) below the measured one, and the stated range covers the measured number.
By their numbers in this assay, from the lowest: compound 1; then compound 3; then compound 2.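

In this assay, the change to 4-hydroxyphenyl gives a 3.2-fold lower number from compound 2 to compound 3 (0.50 log units; beyond the scatter) and so takes back only part of the ground lost with 4-(trifluoromethyl)phenyl. Set against the unsubstituted phenyl ring, hydroxy on the same aromatic carbon gives a 3.1-fold higher number from compound 1 to compound 3 (0.49 log units; beyond the scatter) and leaves compound 3 on the weaker side of compound 1. Until now only trifluoromethyl had been seen to raise the number at this position, whereas these three compounds show that two groups with different hydrogen-bond donor and acceptor counts both stand weaker than hydrogen, with hydroxy the less costly of the two. Nothing available here explains this order.

Going by these compounds, whether a methoxy group, an amine or a carboxylic acid on this carbon would fall closer to compound 1 than hydroxy does remains open, as does whether any group there could bring the number lower than that of compound 1. Also open, on these data alone, is whether hydroxy would give a similar result on another carbon of the same ring.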